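Changing the Sulfonyl Group: Methoxyphenyl to Chlorothiophene

The source may hold more compounds than are shown below. What is called first, only, known or untested is meant among the compounds shown, and "the series" means these compounds.

Compound 1 `O=S(=O)(Nc1ccc2oc(-c3ccc(NS(=O)(=O)c4cccc5nonc45)cc3)nc2c1)c1ccc(Cl)s1`: 13000 nM
Compound 2 `O=S(=O)(Nc1ccc2oc(-c3ccccc3)nc2c1)c1cccc(C(F)(F)F)c1`: > 100000 nM
Compound 3 `COc1cccc(S(=O)(=O)Nc2ccc3oc(-c4ccccc4)nc3c2)c1`: > 100000 nM

Of the compounds shown here, three have been tested in an assay on cells for inhibition of HSP60/HSP10 (Homo sapiens), with a stated time of 60 min; on this read-out higher numbers stand for weaker inhibition and lower numbers for stronger inhibition. For compound 1 the reading is 13000 nM. For compound 2 the reported value of > 100000 nM is a limit of the assay rather than a number. The same holds for compound 3, whose value of > 100000 nM is also a limit. Compound 3 therefore stands at the limit, and the limit of > 100000 nM in this assay, at which 2 of the 3 values shown sit, is where two of the three values sit. Going by the values given here, the only measured single change, a step that the two limits leave unreadable from compound 2 to compound 3, cannot be read because both ends are limits.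

The next compound, compound 4 `O=S(=O)(Nc1ccc2oc(-c3ccccc3)nc2c1)c1ccc(Cl)s1`, differs from compound 3 by 5-chlorothiophen-2-yl in place of 3-methoxyphenyl on a sulfonyl sulfur. Among the compounds with values here, no measured step bears directly on this change; compound 1 carries the same 5-chlorothiophen-2-yl group but differs elsewhere too, and its value shows only that a number inside the assay range is possible. Compound 4 is expected to stay near the limit, and the step of a number no higher from compound 3 to compound 4 (the limit leaves the size open) is expected to be small. The estimate for compound 4 is 100000 nM, within 30000 nM to 300000 nM.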

Compound 4, half-maximal inhibitory concentration: 70000 nM
For compound 4 the middle estimate is 1.4-fold (0.15 log units) above the measured one; low and high end bracket the measured number.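

Placing 5-chlorothiophen-2-yl on the sulfonyl sulfur gives the first real number for this position on the shared core in this assay, where the two earlier compounds with this core gave only limits. From the compounds shown here alone, the swap from 3-methoxyphenyl gives an at least 1.4-fold lower number from compound 3 to compound 4 (0.15 log units; that floor lies within the scatter), so a real gain cannot yet be claimed, although the true size of the step is unknown. Compound 3 remains a limit and not a number, and compound 2 shares that place: the limit of > 100000 nM in this assay, at which 2 of the 4 values shown sit.

Going by these compounds, it remains open whether the chlorine itself matters, as a plain thiophene or a small methyl group on the sulfonyl sulfur would show. Also open, on these data alone, is how much the further group on the core of compound 1, which reads 13000 nM, contributes to its value.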